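From a methylphenyl to a methylfuranyl on the saturated carbon

This account rests on a few compounds, and the source may have more. Where it says the series, first, only, none or still open, it means among the compounds named here.

Of the compounds shown here, two have been measured so far. Compound 1 `COc1cc(N2C(N)=C(C#N)C(c3ccc(O)cc3)C3=C2CC(C)(C)CC3=O)cc(OC)c1OC` gives 10% in a functional assay on Ehrlich cells (Mus musculus) for cytotoxicity, tested at 10 ug/mL (a lower number here means a weaker effect, a higher number a stronger effect of the compound at the concentration tested), while compound 2 `COc1cc(N2C(N)=C(C#N)C(c3ccc(C)cc3)C3=C2CC(C)(C)CC3=O)cc(OC)c1OC` gives 30% in this assay. Among the measured compounds shown here, the only step between measured compounds, a number 20 percentage points higher from compound 1 to compound 2 (beyond the scatter), is modest but lies beyond the scatter. Compound 2 therefore stands highest of the two numbers, with compound 1 nearest and lower by a margin beyond the scatter.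

The account now follows the step from compound 2 to compound 3 `COc1cc(N2C(N)=C(C#N)C(c3ccc(C)o3)C3=C2CC(C)(C)CC3=O)cc(OC)c1OC`, which differs from compound 2 in one place: 5-methylfuran-2-yl in place of 4-methylphenyl on a saturated ring carbon. For the measured compounds named here, no measured step covers an exchange of this kind; the single step on record, a number 20 percentage points higher from compound 1 to compound 2 (beyond the scatter), concerns a different change and gives no guidance here. For that reason the expected step of no change at the digits printed from compound 2 to compound 3 (within the scatter) is set at none beyond the scatter, in either direction. Compound 3 is thus expected to give about 30% in this assay, with a range from 10% to 50%.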

Compound 3, a percentage reported as activity, at one concentration (the size of the read-out at that concentration, not a potency): 21%
Beside the measured number, compound 3's estimate is 9 percentage points above it, within the range that was stated.
By their numbers in this assay, from the lowest: compound 1; then compounds 3 and 2 (each within the scatter of the next).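

In this assay the exchange of 4-methylphenyl for 5-methylfuran-2-yl on the saturated ring carbon gives a number 9 percentage points lower from compound 2 to compound 3 (within the scatter) and so shows that this position can take a five-membered aromatic ring with one oxygen in place of a six-membered ring of carbon only, with no step beyond the scatter. Measured against the 4-hydroxyphenyl group, the same group gives a number 11 percentage points higher from compound 1 to compound 3 (beyond the scatter) and so shows that the higher reading over compound 1 is not confined to 4-methylphenyl, but also appears with a second methyl-bearing ring. Nothing in the material at hand explains either step.

The compounds shown leave open how much of this reading depends on the methyl group of the furan ring, and whether a plain furan-2-yl, a thiophene or a pyridine ring would stay with compounds 2 and 3 or fall toward compound 1. They also leave open how an aromatic ring carrying a dimethylamino group or a carboxylic acid would read at this position, and what potency lies behind these single-concentration numbers.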